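Phenyl for dimethoxyphenyl on a weak nitrite inhibitor

This account rests on a few compounds, and the source may have more. Where it says the series, first, only, none or still open, it means among the compounds named here.

This account follows a pair of weak inhibitors and a third compound built from them. Compound 1 `COc1cc(-c2ccccc2)cc(OC)c1O` gives 50200 nM in a functional assay on BV-2 cells (Mus musculus) for inhibition, read by Griess assay, with a stated time of 24 h; a higher number here means a weaker inhibitor, a lower number a stronger inhibitor. Compound 2 `COc1ccc(-c2cc(OC)c(O)c(Oc3c(OC)cc([C@@H](O)[C@H](O)CO)cc3OC)c2)c(OC)c1`, a larger molecule, gives 48400 nM in this assay. Compound 2 thus holds the lower of the two numbers, but the gap to compound 1 lies within the usual scatter, so the two cannot be told apart on these data.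

Compound 3 `COc1cc(-c2ccccc2)cc(Oc2c(OC)cc([C@@H](O)[C@H](O)CO)cc2OC)c1O` has not yet been measured. It differs from compound 2 in a single change: phenyl in place of 2,4-dimethoxyphenyl on an aromatic carbon. Among the compounds with values here, no step between two measured compounds isolates such a change here, so the expectation rests on the two numbers alone. Since compound 1 and compound 2 sit at the same level, the author expects no step beyond the scatter from compound 2 to compound 3, and estimates the step as a 1.0-fold higher number from compound 2 to compound 3 (0.01 log units; within the scatter). Compound 3 is therefore estimated to give 50000 nM in this assay, with a range from 25000 nM to 100000 nM.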

Compound 3, half-maximal inhibitory concentration: 49300 nM
Compound 3: middle estimate off by 1.0-fold (0.01 log units), on the high side, and the stated range covers the measured number.
By their numbers in this assay, from the lowest: compounds 2, 3 and 1 (each within the scatter of the next).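

In this assay, putting phenyl in place of 2,4-dimethoxyphenyl on this aromatic carbon, para to a hydroxy group, gives a 1.0-fold higher number from compound 2 to compound 3 (0.01 log units; within the scatter). Within the data shown here, this is the first step that isolates one change, and it shows that, for this pair, losing both methoxy groups of the 2,4-dimethoxyphenyl leaves the number unchanged within the scatter. No measurement accompanies this result that could account for it, so the step stands as an observation without an explanation.

The compounds shown cover only these two aromatic groups at this position, so they do not tell whether an amine or a carboxylic acid on the same aromatic carbon would give a clearly different number in this assay. Nor do they tell whether a phenyl carrying a single methoxy group would read the same as the two groups compared here.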